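Chloro Gives Way to Methoxy on the Shared Core

The source may hold more compounds than are shown below. What is called first, only, known or untested is meant among the compounds shown, and "the series" means these compounds.

Measured compounds:
- Compound 1 `CCOc1ccc2oc(/C=C/[S+](C)[O-])cc(=O)c2c1`: in a functional assay on DLD-1 cells (Homo sapiens) for cytotoxicity, with a stated time of 48 h (a lower number here means a stronger inhibitor, a higher number a weaker inhibitor), compound 1 gives 4900 nM
- Compound 2 `CCC(=O)Oc1ccc2oc(/C=C/[S+](C)[O-])cc(=O)c2c1`: in this assay compound 2 gives 9000 nM
- Compound 3 `C[S+]([O-])/C=C/c1cc(=O)c2cc(Cl)ccc2o1`: in this assay compound 3 gives 6500 nM

Among these three numbers compound 3 stands second highest; its nearest neighbour is compound 1 and its furthest is compound 2, yet both gaps fall within the usual scatter, so no order among them can be claimed. Compound 4 `COc1ccc2oc(/C=C/[S+](C)[O-])cc(=O)c2c1` is not yet measured. It differs from compound 3 in one place: methoxy in place of chloro on an aromatic carbon. The step that bears on this change is the reverse direction of a 1.3-fold higher number from compound 1 to compound 3 (0.12 log units; within the scatter), in which an ethoxy group stood where compound 4 carries a methoxy group; that step stayed within the scatter. A step within the scatter is therefore expected again, in either direction, meaning a 1.2-fold lower number from compound 3 to compound 4 (0.07 log units; within the scatter). Compound 4 is estimated at 5500 nM, with a range from 2500 nM to 12000 nM.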

Compound 4, half-maximal inhibitory concentration: 5700 nM
Compound 4: the middle estimate sits 1.0-fold (0.02 log units) below what was measured, within the range that was stated.
By their numbers in this assay, from the lowest: compounds 1, 4, 3 and 2 (each within the scatter of the next).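

In this assay the swap of chloro for methoxy on this aromatic carbon gives a 1.1-fold lower number from compound 3 to compound 4 (0.06 log units; within the scatter) and thus leaves the number unmoved, even though methoxy adds a heavy atom and a hydrogen-bond acceptor. Methoxy also matches the two other oxygen-linked groups, with a 1.6-fold lower number from compound 2 to compound 4 (0.20 log units; within the scatter) for propanoyloxy and a 1.2-fold higher number from compound 1 to compound 4 (0.07 log units; within the scatter) for ethoxy. All four groups at this position now lie within the scatter of one another.

Nothing available explains why these numbers sit so close. As far as these compounds go, whether an amine or a carboxylic acid here would shift the number beyond the scatter remains open.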